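Swapping Fluoro for Cyano on the Outer Ring

The source may report more compounds than this note shows. Statements on the series, on what has been measured and on what is new or still open speak of the compounds shown alone.

Of the compounds shown here, three built on one shared core have been measured in an assay on SH-SY5Y cells for inhibition of Voltage-dependent N-type calcium channel subunit alpha-1B (Homo sapiens), read by FLIPR and calcium flux, with stated times of 600 s and 300 s, in the presence of a further agent that is not named here; on this read-out lower numbers stand for stronger inhibition and higher numbers for weaker inhibition. Compound 1 `NCCCOc1ccc(CNc2nc3ccc(Oc4ccc(O)cc4)cc3s2)cc1` gives 205000 nM. Compound 2 `N=C(N)NCCCOc1ccc(CNc2nc3ccc(Oc4ccc(F)cc4)cc3s2)cc1` gives 244000 nM in this assay. Among the measured compounds shown here, compound 3 `CN(C)CCCOc1ccc(CNc2nc3ccc(Oc4ccc(F)cc4)cc3s2)cc1` gives 40000 nM in this assay, the lowest of the three numbers: the single step between close neighbours, a 6.1-fold lower number from compound 2 to compound 3 (0.79 log units; beyond the scatter), separates it from compound 2, and compound 1 also gives a higher number than compound 3. Compound 4 `CN(C)CCCOc1ccc(CNc2nc3ccc(Oc4ccc(C#N)cc4)cc3s2)cc1` has not yet been measured. It differs from compound 3 by cyano in place of fluoro on an aromatic carbon. For the measured compounds named here, no measured pair differs only at this point: compound 1 carries hydroxy instead of fluoro but also a different chain end, and the step from compound 2 to compound 3 concerns the chain end alone. Going by the values given here, the numbers so far therefore give no pull in either direction. The expected step for compound 4 in this assay is no change at the digits printed from compound 3 to compound 4 (within the scatter), within the scatter. Compound 4 is estimated at 40000 nM, with a range from 10000 nM to 160000 nM.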

Compound 4, half-maximal inhibitory concentration: 105000 nM
Beside the measured number, compound 4's estimate is 2.6-fold (0.42 log units) below it, within the range that was stated.
By their numbers in this assay, from the lowest: compound 3; then compounds 4, 1 and 2 (each within the scatter of the next, the first and the last beyond it).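

Among the compounds shown here, this is the first pair in which only the group on this aromatic carbon changes, with the chain end held the same, so the position can now be read on its own: in this assay, cyano in place of fluoro gives a 2.6-fold higher number from compound 3 to compound 4 (0.42 log units; beyond the scatter) and so weaker inhibition. The position is therefore not indifferent to what it carries, though the change is modest and fluoro remains the better of just these two groups on this chain end. Nothing at hand bears on the reason for this step.

Going by these compounds, whether chloro, methyl or methoxy at this position would give a number closer to that of compound 3 or of compound 4 stays open. On these data alone, it is also open whether cyano in place of fluoro would give a similar step with a piperidine at the chain end or on a longer chain.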